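From compound 2 to compound 4: one fluoro less

The source may hold more compounds than are shown below. What is called first, only, known or untested is meant among the compounds shown, and "the series" means these compounds.

Values so far in a functional assay on the whole organism with Mus musculus as the target, in the rotarod test; on this read-out lower numbers stand for an effect already at smaller amounts and higher numbers for an effect only at larger amounts of compound
Compound 1 `CCN(C)C(=O)/C=C1\CCc2c(F)cc(F)cc21`: 73 mg/kg
Compound 2 `NC(=O)/C=C1\CCc2c(F)cc(F)cc21`: 138 mg/kg
Compound 3 `CC(C)NC(=O)/C=C1\CCc2c(F)cc(F)cc21`: 76 mg/kg

On these numbers, compound 2 (138 mg/kg) cannot be set apart from the other two compounds. Its two steps, a 1.9-fold higher number from compound 1 to compound 2 (0.28 log units; within the scatter) and a 1.8-fold lower number from compound 2 to compound 3 (0.26 log units; within the scatter), are both within the scatter, as is a 1.0-fold higher number from compound 1 to compound 3 (0.02 log units; within the scatter).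

Compound 4 `NC(=O)/C=C1\CCc2ccc(F)cc21` has one change from compound 2: hydrogen in place of fluoro on an aromatic carbon. None of the three measured steps bears directly on this change, since each alters only the group on the carbonyl carbon or the amide nitrogen. The data therefore hold no direct evidence on losing this fluoro, and they offer no basis for choosing a direction.

The expectation rests on compound 2 (138 mg/kg) as the closest measured structure. No step beyond the scatter is expected in this assay. The expected step is small (a 1.1-fold lower number from compound 2 to compound 4 (0.03 log units; within the scatter)). For compound 4 the estimate is 130 mg/kg with an expected range of 65 mg/kg to 260 mg/kg as its limits.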

Compound 4, dose for half-maximal effect: 90 mg/kg
Compound 4: the middle estimate sits 1.4-fold (0.16 log units) above what was measured; the measured number falls inside the stated range.
By their numbers in this assay, from the lowest: compounds 1, 3, 4 and 2 (each within the scatter of the next).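

For the compounds shown here, until now only the group on the carbonyl carbon had varied, so compound 4 gives the first reading on the aromatic ring of the shared core. In this assay, hydrogen in place of fluoro gives a 1.5-fold lower number from compound 2 to compound 4 (0.19 log units; within the scatter), so at this position, ortho to a fused ring, this compound pair shows no difference that can be told from the scatter, and the remaining fluoro, meta to the position, stays in place. No supporting measurement accompanies this result that could say anything about what lies behind it.

On these data alone, it remains open whether a chloro or methoxy group at the same position would read the same way. Also open, as far as these compounds go, is whether removing this fluoro would give a similar result with the ethyl(methyl)amino group of compound 1 or the isopropylamino group of compound 3 on the carbonyl carbon.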